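Swapping the amide cap on a long-chain triazole

The source may hold more compounds than are shown below. What is called first, only, known or untested is meant among the compounds shown, and "the series" means these compounds.

Three compounds share a core in which a long saturated chain links a triazole ring to an amide. Compound 1 `O=C(CCCCCCc1cn(-c2ccccc2-c2ccccc2)nn1)NCc1cccnc1` gives 47% in a functional assay on SH-SY5Y cells (Homo sapiens) for cytotoxicity, read by MTT assay, with a stated time of 48 h, tested at 10 uM (a higher number here means a weaker effect of the compound at the concentration tested, a lower number a stronger effect), compound 2 `O=C(CCCCCCCc1cn(-c2ccccc2-c2ccccc2)nn1)Nc1ccncc1` gives 32%, and compound 3 `O=C(CCCCCCCCc1cn(-c2cnc3ccccc3c2)nn1)Nc1ccncc1` gives 53%. Compound 3 therefore stands with the highest of the three numbers; its gap to compound 1 lies within the scatter, while its gap to compound 2 lies beyond it.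

Compound 4 `O=C(CCCCCCCCc1cn(-c2cnc3ccccc3c2)nn1)NCc1cccnc1` is not yet measured. It differs from compound 3 as follows: (pyridin-3-yl)methyl in place of pyridin-4-yl on an amide-type nitrogen. Within the data shown here, one measured step bears on this, in the opposite direction: a number 15 percentage points lower from compound 1 to compound 2 (beyond the scatter), where ((pyridin-4-yl)carbamoyl)methyl replaced ((pyridin-3-yl)methyl)carbamoyl. Turning that around, a step of similar size upward is expected for compound 4, namely a number 13 percentage points higher from compound 3 to compound 4 (beyond the scatter), since compound 3 already gives 53%.

Compound 4 is thus estimated at 66%, with a range from 52% to 82%.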

Compound 4, a percentage reported as activity, at one concentration (the size of the read-out at that concentration, not a potency): 29%
Compound 4: middle estimate off by 37 percentage points, on the high side, and the stated range ends above it.
By their numbers in this assay, from the lowest: compounds 4 and 2 (each within the scatter of the next); then compounds 1 and 3 (each within the scatter of the next).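

In this assay, (pyridin-3-yl)methyl in place of pyridin-4-yl on the amide-type nitrogen gives a number 24 percentage points lower from compound 3 to compound 4 (beyond the scatter), so with this chain and triazole group the (pyridin-3-yl)methyl cap goes with the stronger effect. The earlier step, a number 15 percentage points lower from compound 1 to compound 2 (beyond the scatter), ran the other way, with the pyridin-4-yl cap on the lower number, so in these four compounds the two caps do not keep one order, and the effect of the cap shifts with the rest of the molecule. Nothing measured here accounts for this reversal.

The chain length and the group on the triazole both differ between the two pairs, and no pair shown separates them. From the compounds shown here alone, how a (pyridin-2-yl)methyl cap, or a carboxylic acid in place of the amide, would read also stays open.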